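Nitro in Place of Chloro: Expected Tolerance of Compound 3

A few compounds are considered here, and "the series" means these few. Any claim that something is new, unique, unknown or untested is made for them only; others in the source may bear on it.

Compound 1 `O=C(/C=C/c1cccc(Cl)c1)Nc1nnc(-c2ccccc2)[nH]1` gives 1470000 nM in an ADME assay on Vero cells (Chlorocebus sabaeus) for cytotoxicity, read by MTT assay, with a stated time of 72 h; a lower number here means that less compound is tolerated, a higher number that more compound is tolerated.
Compound 2 `O=C(/C=C/c1ccc([N+](=O)[O-])s1)Nc1nnc(-c2ccccc2)[nH]1` gives 1670000 nM in this assay.

Among the two measured numbers, compound 1 stands lowest, and its nearest neighbour is compound 2, with a 1.1-fold higher number from compound 1 to compound 2 (0.06 log units; within the scatter). Compound 3 `O=C(/C=C/c1cccc([N+](=O)[O-])c1)Nc1nnc(-c2ccccc2)[nH]1` is the unmeasured compound; it differs from compound 1 by nitro in place of chloro on an aromatic carbon. Going by the values given here, the only step measured so far, a 1.1-fold higher number from compound 1 to compound 2 (0.06 log units; within the scatter), replaced the whole aromatic ring at the end of the chain with a different one, and even that wider change stayed within the scatter. A swap of one substituent on the same ring is a smaller change, so no movement beyond the scatter is expected; the step of a 1.0-fold higher number from compound 1 to compound 3 (0.01 log units; within the scatter) is the estimate. For compound 3 the expected value in this assay is 1500000 nM, with a likely range from 750000 nM to 3000000 nM.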

Compound 3, half-maximal cytotoxic concentration: 1990000 nM
For compound 3 the middle estimate is 1.3-fold (0.12 log units) below the measured one; low and high end bracket the measured number.
By their numbers in this assay, from the lowest: compounds 1, 2 and 3 (each within the scatter of the next).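

In this assay, the step from chloro to nitro on this aromatic carbon gives a 1.4-fold higher number from compound 1 to compound 3 (0.13 log units; within the scatter) as its result, even though nitro carries more heavy atoms than chloro and adds hydrogen-bond acceptors. The earlier step exchanged a whole aromatic ring, whereas this one isolates a single substituent on the same ring, and it shows that these two groups cannot be told apart at this position in this assay. No available evidence offers a reason for this result.

With only chloro and nitro shown on this carbon, it remains open whether the number would stay as close with an amine or a carboxylic acid there. On these data alone, a longer alkyl chain in the same place is equally open, so nothing can yet be said about this position in general.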